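The compounds below may be only part of what the source reports. "The series", "measured", "known", "first", "only" and "open" are said of these compounds alone.

Working notes on the series. The shared core of compound 1 `COc1cccc(NC(=O)CSc2nc(Nc3ccccc3)c3ccccc3n2)c1` gives 21700 nM in a functional assay on MDA-MB-231 cells (Homo sapiens) for inhibition, read by MTT assay, with a stated time of 72 h; on this read-out higher numbers stand for weaker inhibition and lower numbers for stronger inhibition. Among the measured compounds shown here, compound 2 `O=C(CSc1nc(Nc2ccccc2)c2ccccc2n1)Nc1ccc(F)c(Cl)c1` gives 21600 nM; the step of a 1.0-fold lower number from compound 1 to compound 2 (0.00 log units; within the scatter) is the only single-point comparison measured so far, and it sits on the amide-type nitrogen. Compound 3 `C=CC(=O)Nc1cccc(NC(=O)CSc2nc(Nc3ccccc3Br)c3ccccc3n2)c1` gives 15200 nM, the lowest of the three numbers, though within the scatter of both compound 1 and compound 2. For the measured compounds named here, compound 4 `C=CC(=O)Nc1cccc(NC(=O)CSc2nc(Nc3cccc([N+](=O)[O-])c3)c3ccccc3n2)c1` differs from compound 3 by 3-nitrophenyl in place of 2-bromophenyl on a nitrogen on an aromatic ring, a change on the nitrogen on an aromatic ring, where no measured step exists. Going by the values given here, no comparison bears on it; the one known step lay elsewhere and was flat. The expectation for compound 4 is therefore no change beyond the scatter, a 1.0-fold lower number from compound 3 to compound 4 (0.01 log units; within the scatter), estimated at 15000 nM with range 6000 nM to 40000 nM.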

Compound 4, half-maximal inhibitory concentration: > 50000 nM
Compound 4 gave a limit, no number; the forecaster's own chance of this, stated with the estimate: 5%; middle value at least 3.3-fold (0.52 log units) away from the limit.
By their numbers in this assay, from the lowest: compounds 3, 2 and 1 (each within the scatter of the next). At a limit, above all of these: compound 4.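

Among the compounds shown here, the (2-bromophenyl)amino to (3-nitrophenyl)amino change is the first single change to move the read-out beyond the scatter, with an at least 3.2-fold higher number from compound 3 to compound 4 (0.51 log units; beyond the scatter) in this assay. The only earlier step, on the amide-type nitrogen, was flat, so this nitrogen on an aromatic ring is the one place shown where the read-out responds to substitution. Compound 4 gives a limit, not a number: the limit of > 50000 nM in this assay, at which 1 of the 4 values shown sits.

From the compounds shown here alone, whether the step follows the nitro group itself or its place on the ring stays open. Also open, going by these compounds, is what an amine or a carboxylic acid on this ring would give.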